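A Dimethylamino for a Hydroxy: Expected Cell Tolerance

The source may hold more compounds than are shown below. What is called first, only, known or untested is meant among the compounds shown, and "the series" means these compounds.

The set holds three measured compounds and one awaiting measurement, all built on one shared core. Compound 1 `Cc1ccccc1/C=N/NC(=N)NO` carries a methyl on its aromatic ring, compound 2 `N=C(NO)N/N=C/c1ccc(O)cc1` carries a hydroxy, and compound 3 `N/C(=N\O)N/N=C/c1ccccc1O` is an isomer of compound 2 with the hydroxy placed differently.

In an ADME assay on Vero cells (Chlorocebus sabaeus) for cytotoxicity (a higher number here means that more compound is tolerated, a lower number that less compound is tolerated), compound 1 gives > 100000 nM, which is a limit of the assay rather than a number. In this assay compound 2 gives > 100000 nM, again a limit. In this assay compound 3 gives > 100000 nM, also a limit. Compound 2 therefore stands exactly where the other two stand: the limit of > 100000 nM in this assay, at which 3 of the 3 values shown sit. Within the data shown here, since the three measured compounds differ from one another in more than one place, no single step between them can be counted.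

Compound 4 `CN(C)c1ccc(/C=N/NC(=N)NO)cc1` differs from compound 2 by dimethylamino in place of hydroxy on an aromatic carbon. Because the limit of > 100000 nM in this assay, at which 3 of the 3 values shown sit, describes every value seen so far, the step from compound 2 to compound 4 in this assay is expected to be a step that the limit leaves unreadable from compound 2 to compound 4, that is, nothing beyond the scatter. Compound 4 is accordingly estimated at 150000 nM in this assay, with a range from 50000 nM to 400000 nM, and most likely only a limit will be reported.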

Compound 4, half-maximal cytotoxic concentration: > 100000 nM
Compound 4: no number, only a limit (the forecaster's own chance of this, stated with the estimate: 75%); the middle value is on the limit's open side.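

Among these compounds, no step from compound 2 to compound 4 can be read in this assay because both values are limits: the limit of > 100000 nM in this assay, at which 4 of the 4 values shown sit.

The compounds shown leave open where the cytotoxic concentration of any of them lies, and so whether dimethylamino in place of hydroxy on an aromatic carbon alters cell tolerance at all.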